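A few compounds are considered here, and "the series" means these few. Any claim that something is new, unique, unknown or untested is made for them only; others in the source may bear on it.

In an ADME assay on the whole organism with Oryza sativa as the target, tested at 0.1 uM (a lower number here means a stronger effect, a higher number a weaker effect of the compound at the concentration tested), compound 1 `Cc1ccccc1NC(=O)N[C@H](C)c1ccccc1` gives 100%, and its mirror-image partner, compound 2 `Cc1ccccc1NC(=O)N[C@@H](C)c1ccccc1`, gives 100%. Among the compounds with values here, the only measured step, no change at the digits printed from compound 1 to compound 2 (within the scatter), rests on the fact that compounds 1 and 2 differ only in the configuration as drawn: the two compounds share all atoms and bonds and differ only in how the saturated chain carbon is drawn. Compound 3 `CCCCCc1ccc(NC(=O)N[C@@H](C)c2ccccc2)cc1` gives 98% in this assay. Compound 2 thus stands level with compound 1 at the digits shown, the two together the highest of the three numbers, and compound 3 lies within the scatter of compound 2.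

Compound 4 `C[C@H](NC(=O)Nc1ccccc1C(F)(F)F)c1ccccc1` is the next compound for this assay. Its change from compound 2 is trifluoromethyl in place of methyl on an aromatic carbon: a methyl leaves and a trifluoromethyl enters, on an aromatic carbon of a six-membered aromatic ring of carbon only, ortho to a large group. Within the data shown here, no measured step touches the group on that ring; the one step in hand concerns configuration alone and says nothing about a substituent swap. Among the measured compounds shown here, all three numbers so far sit close to the top of the scale, and the values of compound 2 and compound 3 show that a different group on that ring left the reading within the scatter. Compound 4 is therefore expected to give 98%, estimated between 86% and 100%. The expected step of a number 2 percentage points lower from compound 2 to compound 4 (within the scatter) is estimated to be none beyond the scatter.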

Compound 4, a percentage reported as activity, at one concentration (the size of the read-out at that concentration, not a potency): 97%
Compound 4: the middle estimate sits 1 percentage points above what was measured; the range from low to high includes it.
By their numbers in this assay, from the lowest: compounds 4, 3, 1 and 2 (each within the scatter of the next).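

In this assay, trifluoromethyl in place of methyl on an aromatic carbon of a six-membered aromatic ring of carbon only, ortho to a large group, gives a number 3 percentage points lower from compound 2 to compound 4 (within the scatter) in the reading. This is the first step among the compounds shown that changes a substituent at this place rather than configuration alone, and it shows that a group of 4 heavy atoms, 3 of them fluorine, can replace a single carbon there while the reading stays within the scatter at the one concentration tested. The evidence at hand concerns only configuration and offers no explanation for this result.

All four compounds sit close to the top of the scale, so the compounds shown leave open whether any group at this place can move the reading beyond the scatter, for example an amine or a carboxylic acid in place of the methyl. They also leave open whether the mirror-image partner of compound 4 would read level with it, as compound 1 and compound 2 do.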